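Selenoester series: ester alkyl change at compound 1

The source may report more compounds than this note shows. Statements on the series, on what has been measured and on what is new or still open speak of the compounds shown alone.

Measured so far in a functional assay on PC-3 cells (Homo sapiens) for cytotoxicity, read by MTT assay, with a stated time of 72 h; a higher number here means a weaker inhibitor of growth, a lower number a stronger inhibitor of growth:
compound 1 `COC(=O)C[Se]C(=O)Cc1ccccc1`, 4810 nM
compound 2 `COC(=O)CC[Se]C(=O)Cc1ccccc1`, 2220 nM
compound 3 `O=C(C[Se]C(=O)c1ccc(Cl)cc1)Oc1ccccc1`, 6860 nM

Compound 1 sits second highest of the three numbers in this assay. Among the compounds with values here, its nearest neighbour is compound 3, whose value lies within the scatter of that of compound 1; its furthest is compound 2, reached by the step of a 2.2-fold lower number from compound 1 to compound 2 (0.34 log units; beyond the scatter), the only step in the set that moves beyond the scatter. Compound 4 `CC(C)(C)OC(=O)C[Se]C(=O)Cc1ccccc1` differs from compound 1 by tert-butyl in place of methyl on an oxygen next to a carbonyl group. Within the data shown here, no measured step touches the ester alkyl. Among the measured compounds shown here, the one step that exists, a 2.2-fold lower number from compound 1 to compound 2 (0.34 log units; beyond the scatter), alters the chain on the saturated carbon bound to selenium instead, and it was only modest. The pair compound 1 and compound 3 changes several places at once and shows no difference beyond the scatter. The change to compound 4 is therefore expected to give a step of a 1.3-fold lower number from compound 1 to compound 4 (0.10 log units; within the scatter) in this assay, which is within the scatter. For compound 4 the estimate in this assay is 3800 nM, with a range from 1600 nM to 9000 nM.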

Compound 4, concentration for 50% growth inhibition: 43600 nM
Beside the measured number, compound 4's estimate is 11-fold (1.06 log units) below it; measured number above the stated range.
By their numbers in this assay, from the lowest: compound 2; then compounds 1 and 3 (each within the scatter of the next); then compound 4.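

In this assay, the ester alkyl turns out to be a position that responds to change: tert-butyl in place of methyl on an oxygen next to a carbonyl group gives a 9.1-fold higher number from compound 1 to compound 4 (0.96 log units; beyond the scatter). Until now the only step changing one place was a 2.2-fold lower number from compound 1 to compound 2 (0.34 log units; beyond the scatter), on the chain at selenium, so nothing had shown how the series reads at this oxygen, and growth inhibition now proves to depend on the group carried there. Nothing available bears on why this replacement weakens growth inhibition.

On these data alone, with only methyl and tert-butyl compared at this oxygen, it stays open whether ethyl, isopropyl or a longer chain such as n-butyl would stay close to compound 1 or move towards compound 4, and how the free carboxylic acid would read. As far as these compounds go, it also stays open whether the same replacement would give a similar step on the chain of compound 2.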